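Swapping the lactam for a triazole on the shared core

The source may hold more compounds than are shown below. What is called first, only, known or untested is meant among the compounds shown, and "the series" means these compounds.

Within the data shown here, compound 2 `CC(C)C(c1ccc(-c2ccc3cccc(F)c3c2)[nH]c1=O)N1CCCCC1=O` is measured in an ADME assay on microsomes from liver (Rattus norvegicus) for metabolic stability; on this read-out lower numbers stand for a shorter-lived compound and higher numbers for a longer-lived compound; in this assay compound 2 gives 0.102 h, the only number reported for this series. Compound 1 `CC(C)C(Cc1ncc[nH]1)c1ccc(-c2ccc3cccc(F)c3c2)[nH]c1=O` reaches only the limit < 0.0667 h in this assay. Among the measured compounds shown here, the one measured step, an at least 1.5-fold higher number from compound 1 to compound 2 (0.18 log units; that floor lies within the scatter), therefore rests on the limit of < 0.0667 h in this assay, at which 1 of the 2 values shown sits, and its true size is open-ended.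

Compound 3 `CC(C)C(c1nnc[nH]1)c1ccc(-c2ccc3cccc(F)c3c2)[nH]c1=O` is not yet measured. It differs from compound 2 by 4H-1,2,4-triazol-3-yl in place of 2-oxopiperidin-1-yl on a saturated chain carbon bound to an aromatic carbon and a saturated chain carbon. For the measured compounds named here, the only step that bears on it is the one from compound 1 to compound 2, which changed the same position: there a group holding a five-membered aromatic ring with hetero atoms gave way to the 2-oxopiperidin-1-yl group, and the number rose. Compound 3 undoes that exchange in kind, bringing a five-membered aromatic ring with three hetero atoms back into that place. The expected step for compound 3 is therefore downward, a 1.5-fold lower number from compound 2 to compound 3 (0.16 log units; within the scatter), with a real chance that only a limit is reported. Compound 3 is expected to give 0.07 h, within 0.04 h to 0.13 h.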

Compound 3, half-life: 0.552 h
Compound 3: middle estimate off by 7.9-fold (0.90 log units), on the low side, and the stated range ends below it.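

In this assay, among these compounds, the place on a saturated chain carbon bound to an aromatic carbon and a saturated chain carbon now shows a change beyond the scatter, where the only earlier step had a floor within it: a 5.4-fold higher number from compound 2 to compound 3 (0.73 log units; beyond the scatter). A five-membered aromatic ring with hetero atoms therefore does not go with a short half-life at this place as a rule, as 4H-1,2,4-triazol-3-yl gives the highest number of the three and compound 1, which also holds such a ring, gives the lowest, with an at least 8.2-fold higher number from compound 1 to compound 3 (0.91 log units; beyond the scatter). Compound 1 is reported only as a limit, so that step is a floor and its true size stays open: the limit of < 0.0667 h in this assay, at which 1 of the 3 values shown sits.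

The compounds shown do not tell why the number rises, nor whether the difference between compound 1 and compound 3 lies in the ring itself or in the methyl link, as the two change together. A (4H-1,2,4-triazol-3-yl)methyl group or a directly attached 1H-imidazol-2-yl group at this place would separate the two, and a carboxylic acid there remains an open case.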